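A second trifluoromethyl group: estimating compound 4

The source may report more compounds than this note shows. Statements on the series, on what has been measured and on what is new or still open speak of the compounds shown alone.

Compound 1 `S=C(Nc1ccc(Cl)cc1)Nc1ccc2ncnc(Nc3cccc(Br)c3)c2c1` is the reference on the shared core. In a functional assay on MDA-MB-231 cells (Homo sapiens) for inhibition, read by MTT assay, with a stated time of 48 h (a lower number here means a stronger inhibitor of growth, a higher number a weaker inhibitor of growth), compound 1 gives 8200 nM. Compound 2 `FC(F)(F)c1cc(NC(=S)Nc2ccc3ncnc(Nc4cccc(Br)c4)c3c2)ccc1Cl` differs from it by trifluoromethyl in place of hydrogen on an aromatic carbon, and in this assay compound 2 gives 1100 nM, the step being a 7.5-fold lower number from compound 1 to compound 2 (0.87 log units; beyond the scatter). Compound 3 `FC(F)(F)c1cccc(NC(=S)Nc2ccc3ncnc(Nc4cccc(Br)c4)c3c2)c1` differs from compound 1 by 3-(trifluoromethyl)phenyl in place of 4-chlorophenyl on an amide-type nitrogen; in this assay compound 3 gives 1400 nM, which is a 5.9-fold lower number from compound 1 to compound 3 (0.77 log units; beyond the scatter). Compound 2 and compound 3 lie close together, with a 1.3-fold higher number from compound 2 to compound 3 (0.10 log units; within the scatter).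

Compound 4 `FC(F)(F)c1cc(NC(=S)Nc2ccc3ncnc(Nc4cccc(Br)c4)c3c2)cc(C(F)(F)F)c1` has not yet been measured. It differs from compound 3 by trifluoromethyl in place of hydrogen on an aromatic carbon. Going by the values given here, this is the same kind of change as the one from compound 1 to compound 2, not the same one: there the entering group sits ortho to a chloro group and meta to a large group, here it sits meta to a large group and meta to a trifluoromethyl group. The earlier change brought a 7.5-fold lower number from compound 1 to compound 2 (0.87 log units; beyond the scatter), but a smaller gain is expected here because compound 3 already gives 1400 nM with one trifluoromethyl in place. The estimate for compound 4 in this assay is 600 nM, expected to fall between 250 nM and 1500 nM, which means an expected step of a 2.3-fold lower number from compound 3 to compound 4 (0.37 log units; beyond the scatter).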

Compound 4, concentration for 50% growth inhibition: 800 nM
Compound 4: middle estimate off by 1.3-fold (0.12 log units), on the low side; the measured number falls inside the stated range.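

In this assay the trifluoromethyl group entering in place of hydrogen on an aromatic carbon brings a 1.8-fold lower number from compound 3 to compound 4 (0.24 log units; within the scatter), so on this core the change leaves no step beyond the scatter. The same change therefore does not carry over in size from one core to the other: the same change on two cores in this assay, a 7.5-fold lower number (0.87 log units; beyond the scatter) from compound 1 to compound 2 and a 1.8-fold lower number (0.24 log units; within the scatter) from compound 3 to compound 4, 4.3-fold (0.63 log units) apart, beyond the scatter of two such steps. This single pair of steps shows that the size of the step is not transferable between these two cores, but it does not show what sets the gap, whether the place of the entering group or the group already on the ring, chloro in one case and trifluoromethyl in the other, and it gives no rule for any further core.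

The compounds shown carry only chloro and trifluoromethyl on this aromatic ring, so it stays open how a nitrile, a methoxy group or an amine would behave there in this assay. From the compounds shown here alone, the bromo group on the other aromatic ring stays the same in all four compounds, and what replacing it with a fluoro or a methyl group would do also remains open.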